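Stereocentre step from compound 2 to compound 3

The compounds below may be only part of what the source reports. "The series", "measured", "known", "first", "only" and "open" are said of these compounds alone.

The series is read in an ADME assay on Vero cells (Chlorocebus sabaeus) for cytotoxicity, read by resazurin assay, with a stated time of 72 h; on this read-out lower numbers stand for an effect already at smaller amounts and higher numbers for an effect only at larger amounts of compound. In this assay compound 2 `N#C[Se]CC1Cc2ccc(Oc3ccccc3)cc2O1` gives > 20 uM, which is a limit and not a number. Compound 1 `N#C[Se]C[C@H]1Cc2ccc(Oc3ccccc3)cc2O1` gives > 20 uM, which is also a limit. The standing of compound 2 therefore comes down to the limit of > 20 uM in this assay, at which 2 of the 2 values shown sit, and no number fixes its place.

Compound 3 `N#C[Se]C[C@@H]1Cc2ccc(Oc3ccccc3)cc2O1` is the next compound to be read. The change is the two compounds have the same atoms and bonds; at least one stereo element is drawn with a configuration in one of them and without one in the other: 1 of 1 stereo elements differ; a stereocentre at a saturated ring carbon is drawn without a configuration in compound 2 and S in compound 3. Nothing leaves and nothing enters.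

Among the measured compounds shown here, the one measured step of the same kind, at a stereocentre at a saturated ring carbon, is a step that the two limits leave unreadable from compound 1 to compound 2. That comparison rests on (the fact that one of compounds 1 and 2 is drawn with a defined configuration and the other without, at the place where they differ), and it offers no size to carry over. With only limits to go on, no step beyond the usual scatter is expected in this assay, and no direction can be assigned. The expected change is a step that the limit leaves unreadable from compound 2 to compound 3. For compound 3 the estimated value is 25 uM, with an expected range of 14 uM to 50 uM, and a report that is again only a limit is the expected outcome.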

Compound 3, concentration for half-maximal effect: > 20 uM
Compound 3 gave a limit, no number (the forecaster's own chance of this, stated with the estimate: 85%); the middle value is on the limit's open side.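

In this assay compound 3 gives > 20 uM, which is a limit and not a number. No step among compound 1, compound 2 and compound 3 can be read, because all three stop at the same limit: the limit of > 20 uM in this assay, at which 3 of the 3 values shown sit.

Still open, from the compounds shown here alone, is whether the R form in compound 1 and the S form in compound 3 differ at all in this read-out.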